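Moving the hydroxyl on the aryl group flanking the pyridine nitrogen

This account rests on a few compounds, and the source may have more. Where it says the series, first, only, none or still open, it means among the compounds named here.

Compound 1 `Oc1ccc(-c2cc(-c3cccs3)cc(-c3cccc(O)c3)n2)cc1`: 4140 nM
Compound 2 `Oc1ccc(-c2cc(-c3ccsc3)cc(-c3cccc(O)c3)n2)cc1`: 2580 nM
Compound 3 `Oc1cccc(-c2cc(-c3ccoc3)cc(-c3ccccc3O)n2)c1`: > 50000 nM

In a functional assay on HeLa cells (Homo sapiens) for cytotoxicity, read by CCK-8 assay (on this read-out higher numbers stand for weaker inhibition and lower numbers for stronger inhibition), compound 1 gives 4140 nM. Compound 2 gives 2580 nM, and the step of a 1.6-fold lower number from compound 1 to compound 2 (0.21 log units; within the scatter) is within the scatter. For compound 3 this assay reports only a limit, > 50000 nM, as noted in the limit of > 50000 nM in this assay, at which 1 of the 3 values shown sits. Compound 4 `Oc1ccc(-c2cc(-c3ccoc3)cc(-c3cccc(O)c3)n2)cc1` differs from compound 3 by 4-hydroxyphenyl in place of 2-hydroxyphenyl on an aromatic carbon. Among the compounds with values here, no measured step concerns this change; the only measured step, a 1.6-fold lower number from compound 1 to compound 2 (0.21 log units; within the scatter), concerns another position. Compounds 1 and 2, which carry the same 4-hydroxyphenyl and 3-hydroxyphenyl pairing as compound 4, do give numbers. Compound 4 is therefore expected to give a number, around 9000 nM, between 2500 nM and 50000 nM. The expected step is an at least 5.5-fold lower number from compound 3 to compound 4 (0.74 log units; beyond the scatter).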

Compound 4, half-maximal inhibitory concentration: 3310 nM
Beside the measured number, compound 4's estimate is 2.7-fold (0.43 log units) above it, within the range that was stated.
By their numbers in this assay, from the lowest: compounds 2, 4 and 1 (each within the scatter of the next). At a limit, above all of these: compound 3.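

On the aryl group next to the ring nitrogen, 4-hydroxyphenyl in place of 2-hydroxyphenyl gives an at least 15-fold lower number from compound 3 to compound 4 (1.17 log units; beyond the scatter) in this assay, so where the hydroxyl sits on this group counts. Compound 3 has only a limit and not a number: the limit of > 50000 nM in this assay, at which 1 of the 4 values shown sits. Furan-3-yl in place of either thiophene group stays within the scatter, giving a 1.3-fold higher number from compound 2 to compound 4 (0.11 log units; within the scatter) and a 1.3-fold lower number from compound 1 to compound 4 (0.10 log units; within the scatter).

The compounds shown leave open how an amine or a methoxy group would read in place of this hydroxyl. They also leave open whether 2-hydroxyphenyl at this position gives a limit alongside thiophen-2-yl or thiophen-3-yl.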